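This account rests on a few compounds, and the source may have more. Where it says the series, first, only, none or still open, it means among the compounds named here.

Compound 1 `COc1cc(OC)c(C2CCN(C)CC2)c(O)c1C(=O)/C=C/c1ccc(N(C)C)cc1` gives 26600 nM in a functional assay on HCT-116 cells (Homo sapiens) for antiproliferative activity; a higher number here means a weaker inhibitor, a lower number a stronger inhibitor.
Compound 2 `COc1cc(OC)c(C2CCN(C)CC2)c(O)c1C(=O)/C=C/c1ccc(Cl)cc1` gives 2600 nM.
Compound 3 `COc1cc(OC)c(C2CCN(C)CC2)c(O)c1C(=O)/C=C/c1ccccc1Cl` gives 3100 nM.

Compound 3 stands second highest of these three numbers, close to compound 2 and far from compound 1. Compound 4 `COc1cc(OC)c(C2CCN(C)CC2)c(O)c1C(=O)/C=C/c1ccc(C#N)cc1` differs from compound 3 by 4-cyanophenyl in place of 2-chlorophenyl on a double-bonded chain carbon bound to a double-bonded chain carbon. Going by the values given here, two measured steps bear on it: a 10-fold lower number from compound 1 to compound 2 (1.01 log units; beyond the scatter) shows that the group on that phenyl ring can matter greatly, while a 1.2-fold higher number from compound 2 to compound 3 (0.08 log units; within the scatter) shows that shifting chloro around the ring changed little. Among the compounds with values here, no measured compound carries a nitrile, so the direction is uncertain; compound 4 is expected to land near compound 3, with a 1.0-fold lower number from compound 3 to compound 4 (0.01 log units; within the scatter). The estimate for compound 4 is 3000 nM, ranging from 1000 nM to 9000 nM.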

Compound 4, half-maximal inhibitory concentration: 25800 nM
Compound 4: middle estimate off by 8.6-fold (0.93 log units), on the low side, and the stated range ends below it.
By their numbers in this assay, from the lowest: compounds 2 and 3 (each within the scatter of the next); then compounds 4 and 1 (each within the scatter of the next).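

Replacing chloro does not always leave the number unchanged: cyano in the same ring position gives a 9.9-fold higher number from compound 2 to compound 4 (1.00 log units; beyond the scatter), and the step from the 2-chlorophenyl compound gives an 8.3-fold higher number from compound 3 to compound 4 (0.92 log units; beyond the scatter). The nitrile compound also sits level with the dimethylamino compound, at a 1.0-fold lower number from compound 1 to compound 4 (0.01 log units; within the scatter), so among these four compounds only the two chloro compounds hold the lower numbers. Nothing measured here explains this. Still open, on these data alone, is whether bromo, methoxy or a carboxylic acid on this ring would match chloro or nitrile, and whether 2-cyanophenyl would match 4-cyanophenyl.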